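Dropping One Trifluoromethyl Group from a Weak Pair

The compounds below may be only part of what the source reports. "The series", "measured", "known", "first", "only" and "open" are said of these compounds alone.

In a functional assay on SNB-19 cells (Homo sapiens) for inhibition, read by sulforhodamine B assay, with a stated time of 48 h, tested at 0.01 uM (a higher number here means a weaker effect of the compound at the concentration tested, a lower number a stronger effect), compound 1 `COc1cc(Cl)cc(-c2nn(-c3cccc(NC(=O)Nc4ccc(Cl)c(C(F)(F)F)c4)c3)cc2-c2ccncc2)c1` gives 92%. Compound 2 `COc1cc(Cl)cc(-c2nn(-c3cccc(NC(=O)Nc4cc(C(F)(F)F)cc(C(F)(F)F)c4)c3)cc2-c2ccncc2)c1` gives 89% in this assay; the two numbers lie within the usual scatter of each other, so compound 2 stands together with compound 1, and both show only a weak effect at this concentration. Compound 3 `COc1cc(Cl)cc(-c2nn(-c3cccc(NC(=O)Nc4cccc(C(F)(F)F)c4)c3)cc2-c2ccncc2)c1` differs from compound 2 by hydrogen in place of trifluoromethyl on an aromatic carbon. Among the measured compounds shown here, no measured pair shows this change directly. The expected step, a number 2 percentage points higher from compound 2 to compound 3 (within the scatter), is estimated to stay within the scatter, in neither direction. For compound 3 the estimate in this assay is 91%, in a range from 80% to 100%.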

Compound 3, a percentage reported as activity, at one concentration (the size of the read-out at that concentration, not a potency): 98%
Estimate against measurement, compound 3: 7 percentage points below, and the stated range covers the measured number.
By their numbers in this assay, from the lowest: compounds 2, 1 and 3 (each within the scatter of the next).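

In this assay, hydrogen in place of trifluoromethyl on the aromatic carbon gives a number 9 percentage points higher from compound 2 to compound 3 (within the scatter), and hydrogen in place of chloro gives a number 6 percentage points higher from compound 1 to compound 3 (within the scatter). Neither group can therefore be told apart from plain hydrogen on this ring at this concentration, so this weak read-out gives no sign that the second substituent matters. Nothing measured here offers an explanation for this result.

From the compounds shown here alone, an amine or a carboxylic acid on the same aromatic carbon remains open. So does whether these substituents can be told apart at a higher concentration, where a stronger effect might leave room for differences to appear.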